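Methyl added to an aromatic carbon of a soluble amide

The source may report more compounds than this note shows. Statements on the series, on what has been measured and on what is new or still open speak of the compounds shown alone.

Compound 2 `CC(C)(O)[C@H]1CCC[C@H](NC(=O)C2CCN(c3nc4cc(Cl)ccc4o3)CC2)C1` stands at the upper end of the two values shown in a physicochemical assay for solubility, read by nephelometry, in phosphate buffer, at pH 7.4; a higher number here means a more soluble compound, a lower number a less soluble compound. In this assay compound 2 gives > 100000 nM, which is a limit of the assay and not a number (the limit of > 100000 nM in this assay, at which 1 of the 2 values shown sits). Compound 1 `O=C(NC1CCCCC1)C1CCN(c2nc3cc(Cl)ccc3o2)CC1` gives < 3000 nM, also a limit (the limit of < 3000 nM in this assay, at which 1 of the 2 values shown sits). Within the data shown here, the only measured step, an at least 33-fold higher number from compound 1 to compound 2 (1.52 log units; beyond the scatter), concerns a different change and does not bear on the change to compound 3 `Cc1cc2oc(N3CCC(C(=O)N[C@H]4CCC[C@H](C(C)(C)O)C4)CC3)nc2cc1Cl`, which is methyl in place of hydrogen on an aromatic carbon. Among the measured compounds shown here, no measured step sets the size here; a modest fall or none beyond the scatter is expected, an at least 1.2-fold lower number from compound 2 to compound 3 (0.09 log units; that floor lies within the scatter). Compound 3 is expected at 80000 nM, between 30000 nM and 150000 nM.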

Compound 3, solubility: 58000 nM
Estimate against measurement, compound 3: 1.4-fold (0.14 log units) above; the measured number falls inside the stated range.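

In this assay, methyl in place of hydrogen on an aromatic carbon, ortho to a chloro group, gives an at least 1.7-fold lower number from compound 2 to compound 3 (0.23 log units; that floor lies within the scatter). The value of compound 2 is a limit of the assay and not a number, so this step is only a floor, and it does not show that the methyl lowers the number beyond the scatter. Among these compounds, compound 3 gives 58000 nM, the only one of the three values that is not a limit. On these data alone, the true size of the step stays open. So does what an amine or a carboxylic acid would give on this aromatic carbon.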